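Swapping a hexyl chain for a chlorophenyl ring

A few compounds are considered here, and "the series" means these few. Any claim that something is new, unique, unknown or untested is made for them only; others in the source may bear on it.

Compound 1 `CCCCCCNc1nc(SCc2ccc(C(F)(F)F)cc2)nc2ccccc12` is the reference here. In a functional assay on MCF7 cells (Homo sapiens) for cytotoxicity, read by MTT assay, with a stated time of 72 h (a lower number here means a stronger inhibitor, a higher number a weaker inhibitor), compound 1 gives 24300 nM, the lowest of the two plain numbers measured, although its nearest neighbour lies within the usual scatter. Compound 2 `FC(F)(F)c1ccc(CSc2nc(Nc3cccc(Cl)c3)c3ccccc3n2)cc1` gives 25100 nM in this assay. Compound 3 `O=[N+]([O-])c1cccc(Nc2nc(SCc3ccc(C(F)(F)F)cc3)nc3ccccc23)c1` returns only a limit of this assay, > 50000 nM, so no number is known for it beyond (the limit of > 50000 nM in this assay, at which 1 of the 3 values shown sits).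

The change from compound 1 to compound 4 `FC(F)(F)c1ccc(CSc2nc(Nc3ccc(Cl)cc3)c3ccccc3n2)cc1` is 4-chlorophenyl in place of hexyl on a nitrogen on an aromatic ring. The closest measured step is a 1.0-fold higher number from compound 1 to compound 2 (0.01 log units; within the scatter), where a 3-chlorophenyl entered instead: the number barely moved. A different aromatic group gave an at least 2.0-fold higher number from compound 1 to compound 3 (0.31 log units; beyond the scatter), and an at least 1.9-fold higher number from compound 2 to compound 3 (0.29 log units; that floor lies within the scatter) shows what swapping nitro for chloro did. Since a chlorophenyl on that nitrogen left the number essentially unchanged in the one measured case, a step of a 1.0-fold higher number from compound 1 to compound 4 (0.01 log units; within the scatter) is expected, that is, no change beyond the scatter. Compound 4 is therefore estimated at 25000 nM, with a range from 11000 nM to 50000 nM in this assay.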

Compound 4, half-maximal inhibitory concentration: 21500 nM
Estimate against measurement, compound 4: 1.2-fold (0.07 log units) above; the measured number falls inside the stated range.
By their numbers in this assay, from the lowest: compounds 4, 1 and 2 (each within the scatter of the next). At a limit, above all of these: compound 3.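

In this assay, a second chlorophenyl ring again leaves the number where it was, with a 1.1-fold lower number from compound 1 to compound 4 (0.05 log units; within the scatter), so on this nitrogen the hexyl chain and either chlorophenyl ring cannot be told apart. Exchanging one chlorophenyl ring for the other also has no visible effect, with a 1.2-fold lower number from compound 2 to compound 4 (0.07 log units; within the scatter), so the place of the chlorine on the ring does not register in these two compounds. The step with an at least 2.3-fold lower number from compound 3 to compound 4 (0.36 log units; beyond the scatter) is the first chlorophenyl comparison with the 3-nitrophenyl compound to clear the scatter, although it is only a floor, as compound 3 stands at a limit: the limit of > 50000 nM in this assay, at which 1 of the 4 values shown sits.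

As far as these compounds go, it remains open how a shorter chain such as butyl, a benzyl group or a ring carrying an amine or a carboxylic acid would read on this nitrogen. Whether any group here can bring the number down beyond the scatter is also unanswered.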